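A few compounds are considered here, and "the series" means these few. Any claim that something is new, unique, unknown or untested is made for them only; others in the source may bear on it.

Working notes on the series. Compound 1 `CC1(COC(=O)N2CC3COCC(C2)C3Oc2ncnc(Nc3ccc(C#N)cc3Cl)c2F)COC1` is the weaker of the two measured compounds: in a functional assay on HEK293 cells for agonist activity at Glucose-dependent insulinotropic receptor (Homo sapiens), read by cAMP accumulation, with a stated time of 30 min (a lower number here means a smaller maximal response, a higher number a larger maximal response), compound 1 gives 41%, while compound 2 `CC1(OC(=O)N2C[C@H]3COC[C@@H](C2)[C@@H]3Oc2ncnc(Nc3c(F)cccc3F)c2F)CC1` gives 78%, a gap beyond the usual scatter. Compound 2 differs from compound 1 in more than one place, so no single change can be read from it. Compound 3 `N#Cc1ccc(Nc2ncnc(OC3C4COCC3CN(C(=O)OC3CCC3)C4)c2F)c(Cl)c1` is not yet measured; it differs from compound 1 by one change, (cyclobutyl in place of (3-methyloxetan-3-yl)methyl on an oxygen next to a carbonyl group). Nothing measured here isolates that change. The step from compound 1 to compound 3 is expected to be small, a number 7 percentage points higher from compound 1 to compound 3 (within the scatter), perhaps slightly upward but not clearly beyond the scatter. Compound 3 is estimated at 48%, within 30% to 70%.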

Compound 3, largest response reached (reported as percent of maximum), in percent of the reference or control that the assay uses: 51%
Estimate against measurement, compound 3: 3 percentage points below; the measured number falls inside the stated range.
By their numbers in this assay, from the lowest: compounds 1 and 3 (each within the scatter of the next); then compound 2.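

In this assay, cyclobutyl in place of (3-methyloxetan-3-yl)methyl on an oxygen next to a carbonyl group gives a number 10 percentage points higher from compound 1 to compound 3 (within the scatter). This single-place step shows that, on the core of compound 1, a four-membered ring of carbon only can stand in for the oxetane-bearing group without a change beyond the scatter. No measurement shown here offers an explanation for this result. As far as these compounds go, whether an amine, a carboxylic acid or a longer chain at this place would shift the response remains open. The gap to compound 2 also cannot be assigned to any one place.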